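A few compounds are considered here, and "the series" means these few. Any claim that something is new, unique, unknown or untested is made for them only; others in the source may bear on it.

In a functional assay on the whole organism (strain Sprague-Dawley) for inhibition, with Rattus norvegicus as the target, with a stated time of 10 min (a lower number here means that less compound is needed, a higher number that more compound is needed for the effect), compound 1 (`Nc1ccccc1-c1ncc(C(=O)O)c(=O)[nH]1`) gives 50 mg/kg and compound 2 (`CCOc1ccc(C(=O)O)cc1-c1ncc(C(=O)O)c(=O)[nH]1`) gives 25 mg/kg, two values that lie within the usual scatter of each other. Compound 3 (`CCOc1ccc(S(N)(=O)=O)cc1-c1ncc(C(=O)O)c(=O)[nH]1`) differs from compound 2 at one place, with sulfamoyl in place of carboxy on an aromatic carbon, para to an ethoxy group: sulfamoyl in place of carboxy on an aromatic carbon. Going by the values given here, no measured pair shows what this exchange does, and no step beyond the scatter is expected in this assay, in either direction. The estimated step is a 1.2-fold higher number from compound 2 to compound 3 (0.08 log units; within the scatter). For compound 3 the expected value is 30 mg/kg, with an estimated range of 8 mg/kg to 100 mg/kg.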

Compound 3, dose for 50% inhibition: > 50 mg/kg
Compound 3 was reported as a limit (the forecaster's own chance of this, stated with the estimate: 15%); at least 1.6-fold (0.22 log units) between middle value and limit.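

Going by these compounds alone, exchanging carboxy for sulfamoyl at this position, para to an ethoxy group, gives the first read on this change in this assay, as an at least 2.0-fold higher number from compound 2 to compound 3 (0.30 log units; that floor lies within the scatter). Compound 3 has only a limit, not a number: the limit of > 50 mg/kg in this assay, at which 1 of the 3 values shown sits. Sulfamoyl therefore shows no sign of a gain over carboxy here, but a real loss is not established either.

As far as these compounds go, the true value of compound 3 remains open. So does whether a primary amide at this place, or a longer chain in place of ethoxy, would change the dose needed.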